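Swapping Hydroxymethyl for Isopropyl at the Amide Carbonyl

The compounds below may be only part of what the source reports. "The series", "measured", "known", "first", "only" and "open" are said of these compounds alone.

Compound 1, `C#CC(=O)N(Cc1ccc(OC)c(O)c1)c1cc(OC)c(OC)c(OC)c1`: 170 nM
Compound 2, `COc1ccc(CN(C(=O)CBr)c2cc(OC)c(OC)c(OC)c2)cc1O`: 140 nM
Compound 3, `COc1ccc(CN(C(=O)CO)c2cc(OC)c(OC)c(OC)c2)cc1O`: 160 nM

All three were tested in a functional assay on MGC-803 cells (Homo sapiens) for inhibition, read by MTT assay, with a stated time of 48 h; on this read-out lower numbers stand for stronger inhibition and higher numbers for weaker inhibition. Compound 3 has the second highest number of the three, but the steps of a 1.1-fold lower number from compound 1 to compound 3 (0.03 log units; within the scatter) and a 1.1-fold higher number from compound 2 to compound 3 (0.06 log units; within the scatter) both sit within the scatter, so the three compounds cannot be separated. Compound 4, `COc1ccc(CN(C(=O)C(C)C)c2cc(OC)c(OC)c(OC)c2)cc1O`, differs from compound 3 only at the carbonyl carbon: isopropyl in place of hydroxymethyl on a carbonyl carbon. Going by the values given here, the steps that bear on this are those that likewise change the group on that carbonyl carbon: a 1.2-fold lower number from compound 1 to compound 2 (0.08 log units; within the scatter), a 1.1-fold lower number from compound 1 to compound 3 (0.03 log units; within the scatter) and a 1.1-fold higher number from compound 2 to compound 3 (0.06 log units; within the scatter), none beyond the scatter. Three changes at the same position left this assay unmoved, so no step beyond the scatter is expected here either. Compound 4 is therefore estimated at 180 nM, with a range of 90 nM to 360 nM, an expected step of a 1.1-fold higher number from compound 3 to compound 4 (0.05 log units; within the scatter).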

Compound 4, half-maximal inhibitory concentration: 210 nM
The estimate for compound 4 lay 1.2-fold (0.07 log units) below the measured number, within the range that was stated.
By their numbers in this assay, from the lowest: compounds 2, 3, 1 and 4 (each within the scatter of the next).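

Isopropyl, with no hydrogen-bond donor or acceptor, takes the place of hydroxymethyl, which has one of each, yet in this assay the step (a 1.3-fold higher number from compound 3 to compound 4 (0.12 log units; within the scatter)) stays within the scatter. The same holds for the swaps from bromomethyl (a 1.5-fold higher number from compound 2 to compound 4 (0.18 log units; within the scatter)) and from ethynyl (a 1.2-fold higher number from compound 1 to compound 4 (0.09 log units; within the scatter)), so all four groups on this carbonyl carbon remain indistinguishable. No available measurement explains this tolerance. Going by these compounds, whether an amine, a carboxylic acid or a longer chain on this carbonyl carbon would also stay within the scatter remains open.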